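This account rests on a few compounds, and the source may have more. Where it says the series, first, only, none or still open, it means among the compounds named here.

Measured in an ADME assay on WI-38 cells (Homo sapiens) for cytotoxicity, read by sulforhodamine B assay, with a stated time of 24 h; on this read-out higher numbers stand for weaker inhibition and lower numbers for stronger inhibition:
- Compound 1 `O=C1Nc2ccc(S(=O)(=O)N3CCOCC3)cc2/C1=N/c1ccc(Br)cc1`: 372000 nM
- Compound 2 `O=C1Nc2ccc(S(=O)(=O)N3CCOCC3)cc2/C1=N/c1ccc(O)cc1`: 259000 nM
- Compound 3 `O=C1Nc2ccc(S(=O)(=O)N3CCOCC3)cc2/C1=N/c1cccc(C(F)(F)F)c1`: 226000 nM

In this assay, compound 3 gives 226000 nM, which cannot be separated from the other two values. The steps reaching it are a 1.6-fold lower number from compound 1 to compound 3 (0.22 log units; within the scatter) and a 1.1-fold lower number from compound 2 to compound 3 (0.06 log units; within the scatter).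

Compound 4 `CC(=O)N/N=C1\C(=O)Nc2ccc(S(=O)(=O)N3CCOCC3)cc21` carries acetamido in place of 3-(trifluoromethyl)phenyl on a double-bonded nitrogen. These same two steps bear on this change, since each swaps the group on that nitrogen. Among the compounds with values here, the remaining step, a 1.4-fold lower number from compound 1 to compound 2 (0.16 log units; within the scatter), changes only one substituent of that group. Within the data shown here, all three steps are small, but none brings acetamido onto that nitrogen, so the data offer no direct precedent and the uncertainty is wide.

In this assay, no step beyond the scatter is therefore expected, and no direction is favoured. The expected step is a 1.1-fold higher number from compound 3 to compound 4 (0.04 log units; within the scatter). The estimate for compound 4 is 250000 nM, with an expected range from 100000 nM to 600000 nM.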

Compound 4, half-maximal inhibitory concentration: 325000 nM
Estimate against measurement, compound 4: 1.3-fold (0.11 log units) below; the range from low to high includes it.
By their numbers in this assay, from the lowest: compounds 3, 2, 4 and 1 (each within the scatter of the next).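

Across this assay the group on the double-bonded nitrogen no longer needs to be an aromatic ring: acetamido, with no ring and fewer heavy atoms, gives a number inside the scatter of all three aryl compounds (a 1.4-fold higher number from compound 3 to compound 4 (0.16 log units; within the scatter); a 1.3-fold higher number from compound 2 to compound 4 (0.10 log units; within the scatter); a 1.1-fold lower number from compound 1 to compound 4 (0.06 log units; within the scatter)). The swap also brings in a hydrogen-bond donor and a hydrogen-bond acceptor that 3-(trifluoromethyl)phenyl does not have, and the read-out still cannot be told apart from the earlier values. No supporting measurement is available to explain this lack of separation.

The compounds shown leave open whether an amine, a carboxylic acid or a longer chain on that nitrogen would also stay within the scatter. They also leave open whether any group at this place can move the number beyond it.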